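This account rests on a few compounds, and the source may have more. Where it says the series, first, only, none or still open, it means among the compounds named here.

In a functional assay on HT-29 cells (Homo sapiens) for antiproliferative activity, read by sulforhodamine B assay, with a stated time of 48 h (a lower number here means a stronger inhibitor, a higher number a weaker inhibitor), three compounds have been measured:
compound 1 `Cc1ccc(NS(=O)(=O)c2ccc(N3CCNC3=O)cc2)cc1`: 480 nM
compound 2 `O=C1NCCN1c1ccc(S(=O)(=O)Nc2ccc(I)cc2)cc1`: 650 nM
compound 3 `CCc1ccc(NS(=O)(=O)c2ccc(N3CCNC3=O)cc2)cc1`: 660 nM

Compound 3 lies within the scatter of both others, with a 1.4-fold higher number from compound 1 to compound 3 (0.14 log units; within the scatter) and a 1.0-fold higher number from compound 2 to compound 3 (0.01 log units; within the scatter). Compound 4 `CCCCCCCc1ccc(NS(=O)(=O)c2ccc(N3CCNC3=O)cc2)cc1` differs from compound 3 by pentyl in place of hydrogen on a saturated chain carbon, two bonds along the chain from an aromatic carbon, so ethyl becomes heptyl. Within the data shown here, the closest precedent is methyl to ethyl, a 1.4-fold higher number from compound 1 to compound 3 (0.14 log units; within the scatter), and a 1.4-fold higher number from compound 1 to compound 2 (0.13 log units; within the scatter) also stays within the scatter. Neither covers a chain this long, so a step somewhat beyond the scatter, towards a higher number, is expected in this assay. The expected change is a 2.3-fold higher number from compound 3 to compound 4 (0.36 log units; beyond the scatter). For compound 4 the estimated value is 1500 nM, within an expected range from 400 nM to 6000 nM.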

Compound 4, half-maximal inhibitory concentration: > 1000 nM
Compound 4 ended at the assay's limit; the forecaster's own chance of this, stated with the estimate: 10%; the middle value does not contradict the limit.
By their numbers in this assay, from the lowest: compounds 1, 2 and 3 (each within the scatter of the next). At a limit, above all of these: compound 4.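

In this assay compound 4, with heptyl in place of ethyl, gives > 1000 nM, which is a limit of the assay and not a number. The steps to it are therefore floors: an at least 1.5-fold higher number from compound 3 to compound 4 (0.18 log units; that floor lies within the scatter), an at least 1.5-fold higher number from compound 2 to compound 4 (0.18 log units; that floor lies within the scatter) and an at least 2.0-fold higher number from compound 1 to compound 4 (0.31 log units; beyond the scatter). Only the last clears the scatter, so heptyl separates from the methyl of compound 1, which the ethyl of compound 3 did not.

On these data alone, the true value of compound 4 stays open. So does whether a butyl chain, or a chain carrying an amine, would stay within the scatter of compound 3.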